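Bringing an aryl ring back onto the core

This account rests on a few compounds, and the source may have more. Where it says the series, first, only, none or still open, it means among the compounds named here.

Compound 1 `CC(C)Cc1ccc(C(C)c2nnc3sc(-c4ccc(Cl)cc4Cl)nn23)cc1`: 80.3%
Compound 2 `CC(C)Cc1ccc(C(C)c2nnc3sc(COc4ccc(Cl)cc4Cl)nn23)cc1`: 38.6%

Among the measured compounds shown here, in a functional assay on the whole organism (strain Wistar albino) for inhibition, with Rattus norvegicus as the target, read by paw edema, with a stated time of 4 h, at a dose of 70 mg/kg by the oral route (a higher number here means more inhibition at the dose given (going by the name of the read-out), a lower number less inhibition), compound 2 gives 38.6%, the lower of the two numbers measured so far; the only neighbour is compound 1, and the step of a number 41.7 percentage points lower from compound 1 to compound 2 (beyond the scatter) lies beyond the scatter. Compound 3 `CC(C)Cc1ccc(C(C)c2nnc3sc(-c4ccccc4N)nn23)cc1` differs from compound 2 in one place: 2-aminophenyl in place of (2,4-dichlorophenoxy)methyl on an aromatic carbon. For the measured compounds named here, no measured pair shows exactly this change. Going by the values given here, what bears on it is the single step of a number 41.7 percentage points lower from compound 1 to compound 2 (beyond the scatter), which shows that a ring joined straight to the core gave the far higher number while the ring held off through an extra link gave the lower one. Compound 3 again joins a ring straight to the core, so an increase is expected, though the new ring differs from that of compound 1. The expected step is a number 26.4 percentage points higher from compound 2 to compound 3 (beyond the scatter). Compound 3 is therefore estimated at 65%, with a range from 45% to 85%.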

Compound 3, a percentage reported as inhibition, in the whole organism at one dose (the size of the read-out at that dose, not a potency): 57.6%
Beside the measured number, compound 3's estimate is 7.4 percentage points above it; low and high end bracket the measured number.
By their numbers in this assay, from the lowest: compound 2; then compound 3; then compound 1.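

In this assay, a ring joined straight to the core again gives the higher number, with a step (a number 19 percentage points higher from compound 2 to compound 3 (beyond the scatter)), so this advantage over the (2,4-dichlorophenoxy)methyl group is not confined to the 2,4-dichlorophenyl ring of compound 1. Direct attachment alone does not settle the outcome, however: with the ring joined straight to the core in both compounds, changing only what the ring carries still gives a step (a number 22.7 percentage points lower from compound 1 to compound 3 (beyond the scatter)). Nothing available explains why either step occurs.

The compounds shown leave open whether the difference between compound 1 and compound 3 follows the loss of the chlorines or the gain of the amino group. An unsubstituted phenyl ring or a 2-chlorophenyl ring at this position could help separate those two changes.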